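Ethyl amide series: aryl substituent swap, solubility outlook

The compounds below may be only part of what the source reports. "The series", "measured", "known", "first", "only" and "open" are said of these compounds alone.

Three measured compounds share a urea-linked piperidine core with an amide on the ring nitrogen. Compound 1 `O=C(Nc1ccc(C(F)(F)F)c(F)c1)NC1CCN(C(=O)C2CC2)CC1` carries a cyclopropyl on the carbonyl carbon; in a physicochemical assay for solubility, read by mass spectrometry, in phosphate buffer, with a stated time of 24 h, at pH 7.4 (on this read-out lower numbers stand for lower solubility and higher numbers for higher solubility), compound 1 gives 0.46 ug/mL. Compound 2 `CCC(=O)N1CCC(NC(=O)Nc2ccc(C(F)(F)F)c(F)c2)CC1` carries an ethyl at the same place and gives 3.9 ug/mL. Compound 3 `O=C(Nc1ccc(C(F)(F)F)c(F)c1)NC1CCN(C(=O)C2CCOCC2)CC1` carries an oxan-4-yl and gives 42 ug/mL.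

Among these three numbers compound 2 stands second highest: an 8.5-fold higher number from compound 1 to compound 2 (0.93 log units; beyond the scatter), an 11-fold higher number from compound 2 to compound 3 (1.03 log units; beyond the scatter), and a 91-fold higher number from compound 1 to compound 3 (1.96 log units; beyond the scatter).

Compound 4 `CCC(=O)N1CCC(NC(=O)Nc2ccc(OC(F)(F)F)c(F)c2)CC1` keeps the ethyl amide of compound 2 and changes only the aromatic ring: trifluoromethoxy in place of trifluoromethyl on an aromatic carbon

None of the three measured steps touches the aromatic ring; every one of them changes the group on the carbonyl carbon. For the measured compounds named here, those steps therefore do not bear on the change from compound 2 to compound 4, and the data give no comparable pair for this position. Without a bearing step, the expectation for this assay is a step not beyond the scatter, in no preferred direction; the expected step is a 1.0-fold higher number from compound 2 to compound 4 (0.01 log units; within the scatter). Compound 4 is therefore estimated at 4 ug/mL, within a range of 1.5 ug/mL to 11 ug/mL.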

Compound 4, solubility: 11 ug/mL
Compound 4: the middle estimate sits 2.8-fold (0.44 log units) below what was measured; the range from low to high includes it.
By their numbers in this assay, from the lowest: compound 1; then compound 2; then compound 4; then compound 3.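

The aromatic carbon para to a large group and ortho to a fluoro group now has its first readout in this assay, since all earlier steps changed only the group on the carbonyl carbon: with the ethyl amide held fixed, trifluoromethoxy in place of trifluoromethyl gives a 2.8-fold higher number from compound 2 to compound 4 (0.45 log units; beyond the scatter). The position is therefore not silent in this read-out, and a change confined to the aromatic ring moves the number by more than the usual scatter. Trifluoromethoxy brings 5 heavy atoms and 1 hydrogen-bond acceptor where trifluoromethyl has 4 heavy atoms and 0 hydrogen-bond acceptors, but no measurement shown connects either difference with this step.

From the compounds shown here alone, it remains open whether the same swap gives a step of similar size and direction on the cyclopropyl amide of compound 1 or the oxan-4-yl amide of compound 3, which would show whether the two positions act independently. The compounds shown also leave open how a nitrile, a methoxy group or an amine at this aromatic carbon would read in this assay.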